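A few compounds are considered here, and "the series" means these few. Any claim that something is new, unique, unknown or untested is made for them only; others in the source may bear on it.

Compound 1 `COc1cc(-c2cc(/C=C/C(=O)c3ccc(N)cc3)[nH]n2)cc(OC)c1OC` is one of three compounds tested in a functional assay on KM12 cells (Homo sapiens) for inhibition, read by sulforhodamine B assay, with a stated time of 48 h; on this read-out lower numbers stand for higher toxicity in this test and higher numbers for lower toxicity in this test. Compound 1 gives 7270 nM, the highest of the two plain numbers shown. Compound 2 `COc1ccc(-c2cc(/C=C/C(=O)c3ccc(OC)c(OC)c3)[nH]n2)cc1` gives 7010 nM, a number that sits within the scatter of compound 1. Compound 3 `COc1cc(-c2cc(/C=C/C(=O)c3ccc(Cl)c(Cl)c3)[nH]n2)cc(OC)c1OC` gives only > 100000 nM, which is a limit of the assay rather than a number. Among the measured compounds shown here, the only step measured between compounds that differ in one place, an at least 13-fold higher number from compound 1 to compound 3 (1.13 log units; beyond the scatter), puts 3,4-dichlorophenyl in place of 4-aminophenyl on the carbonyl carbon and ends at the limit of > 100000 nM in this assay, at which 1 of the 3 values shown sits.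

Compound 4 `COc1ccc(-c2cc(/C=C/C(=O)c3ccc(N)cc3)[nH]n2)cc1OC` differs from compound 1 elsewhere: hydrogen in place of methoxy on an aromatic carbon. For the measured compounds named here, no measured step touches this part of the molecule; the step from compound 1 to compound 3 alters the carbonyl side, and compound 2 differs from compound 1 in more than one place, so its value only shows where a related compound lands. For compound 4 the expected step is a 1.1-fold higher number from compound 1 to compound 4 (0.04 log units; within the scatter), no larger than the scatter. Compound 4 is therefore estimated to give about 8000 nM in this assay, within a range from 3000 nM to 25000 nM.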

Compound 4, concentration lethal to 50% of the cells: 6670 nM
Compound 4: middle estimate off by 1.2-fold (0.08 log units), on the high side, and the stated range covers the measured number.
By their numbers in this assay, from the lowest: compounds 4, 2 and 1 (each within the scatter of the next). At a limit, above all of these: compound 3.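

Putting hydrogen in place of methoxy on this aromatic carbon, which is ortho to a methoxy group and meta to a large group, gives a 1.1-fold lower number from compound 1 to compound 4 (0.04 log units; within the scatter) in this assay. Among the compounds shown here, this is the first measured step on this side of the molecule, and it shows that this one methoxy group can be exchanged for hydrogen without a change beyond the scatter, unlike the large step on the carbonyl side. Nothing measured here gives a reason for this outcome.

The compounds shown compare only methoxy and hydrogen at this position, so it remains open how a hydroxyl or an ethoxy group would behave there. From the compounds shown here alone, it is also open whether the same exchange would leave the number unchanged with a 3,4-dichlorophenyl on the carbonyl carbon.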